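A Weakly Active Hydrazone Series Near the Assay Limit

The compounds below may be only part of what the source reports. "The series", "measured", "known", "first", "only" and "open" are said of these compounds alone.

In a functional assay on PC-3 cells (Homo sapiens) for inhibition (a higher number here means a weaker inhibitor, a lower number a stronger inhibitor), the three measured compounds share one core and differ only in the aromatic group on a carbon with a double bond to nitrogen. Compound 1 `Cc1c(C(=O)N/N=C\c2cccc(F)c2)oc2cccc(O)c12` reaches only the limit of the assay, >= 40000 nM. Compound 2 `Cc1c(C(=O)N/N=C\c2ccco2)oc2cccc(O)c12` likewise gives only a limit, >= 40000 nM. For the measured compounds named here, compound 3 `COc1ccccc1/C=N\NC(=O)c1oc2cccc(O)c2c1C` is the sole compound with a measured number, 32700 nM. The two steps toward it, an at least 1.2-fold lower number from compound 1 to compound 3 (0.08 log units; that floor lies within the scatter) and an at least 1.2-fold lower number from compound 2 to compound 3 (0.08 log units; that floor lies within the scatter), both have floors that fall within the scatter, so they do not show that the 2-methoxyphenyl group truly helps; they only show that compound 3 sits a little under the limit (the limit of >= 40000 nM in this assay, at which 2 of the 3 values shown sit).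

Compound 4 `Cc1c(C(=O)N/N=C\c2cc(Cl)ccc2O)oc2cccc(O)c12` carries the change (5-chloro-2-hydroxyphenyl in place of 2-methoxyphenyl on a carbon with a double bond to nitrogen). Going by the values given here, no measured step exchanges a methoxy group for a hydroxy group or adds a chlorine, so nothing measured bears directly on this change. Every aromatic group measured so far left the number at or near the limit (the limit of >= 40000 nM in this assay, at which 2 of the 3 values shown sit). For compound 4 the expected step is therefore a 1.1-fold lower number from compound 3 to compound 4 (0.04 log units; within the scatter), a size that lies within the scatter. The estimate for compound 4 is 30000 nM, ranging from 10000 nM to 80000 nM, with a real chance that only a limit is reported again.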

Compound 4, half-maximal inhibitory concentration: 3120 nM
Beside the measured number, compound 4's estimate is 9.6-fold (0.98 log units) above it; measured number outside the range, below it.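

In this assay, for the compounds shown here, the aromatic group on a carbon with a double bond to nitrogen proves able to move the number by a large amount: 5-chloro-2-hydroxyphenyl in place of 2-methoxyphenyl gives a 10-fold lower number from compound 3 to compound 4 (1.02 log units; beyond the scatter), the first step printed as clearly beyond the scatter. Compared with the furan-2-yl and 3-fluorophenyl compounds, each of which gave only a limit of the assay, the same group gives an at least 12-fold lower number from compound 2 to compound 4 (1.10 log units; beyond the scatter) and an at least 12-fold lower number from compound 1 to compound 4 (1.10 log units; beyond the scatter), and both sizes are floors, as each starts from a limit. This position had until now shown no clear gain, with most values resting at the top of the range that can be read: the limit of >= 40000 nM in this assay, at which 2 of the 4 values shown sit.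

The change brought in a chlorine and replaced a methoxy group with a hydroxy group in one move, so the compounds shown do not tell which of the two accounts for the gain, or whether both are needed. Also open, from the compounds shown here alone, is what a phenyl ring carrying only the chlorine or only the hydroxy group would give, and whether a bromine in place of the chlorine or an amine in place of the hydroxy group would keep the gain.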